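Swapping the Amide Aryl Group in a Sulfonamide Series

The source may hold more compounds than are shown below. What is called first, only, known or untested is meant among the compounds shown, and "the series" means these compounds.

Of the compounds shown here, three built on one shared core have been measured in an assay on MDA-MB-231 cells for binding affinity to C-X-C chemokine receptor type 4 (Homo sapiens), read by immunofluorescence and microscopy, with stated times of 10 min and 30 min; a higher number here means that more compound is needed for the effect, a lower number that less compound is needed. Compound 1 `O=C(NCc1ccc(CNS(=O)(=O)c2ccccc2)cc1)c1cccc(F)c1` gives 100 nM, compound 2 `O=C(NCc1ccc(CNS(=O)(=O)c2ccccc2)cc1)c1ccc(F)cc1` gives 100 nM, and compound 3 `COc1ccc(C(=O)NCc2ccc(CNS(=O)(=O)c3ccccc3)cc2)cc1` gives 1000 nM. The step of no change at the digits printed from compound 1 to compound 2 (within the scatter), 4-fluorophenyl in place of 3-fluorophenyl on a carbonyl carbon, makes no real difference. Compound 3 stands highest of the three numbers: both a 10-fold higher number from compound 1 to compound 3 (1.00 log units; beyond the scatter) and a 10-fold higher number from compound 2 to compound 3 (1.00 log units; beyond the scatter) set it well apart from the two fluoro compounds, so compound 3 needs the most material of the three to produce the effect.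

Compound 4 `O=C(NCc1ccc(CNS(=O)(=O)c2ccccc2)cc1)c1cccnc1` has not yet been measured. It differs from compound 3 in one place: pyridin-3-yl in place of 4-methoxyphenyl on a carbonyl carbon. Among the measured compounds shown here, no measured step contains a pyridin-3-yl group, so the only guide is that the methoxy compound sits well above the fluoro compounds, as a 10-fold higher number from compound 2 to compound 3 (1.00 log units; beyond the scatter) shows. For the measured compounds named here, removing the 4-methoxyphenyl group is therefore expected to lower the number, but how far is uncertain, since the entering pyridin-3-yl has no counterpart among the measured compounds. The step of a 3.3-fold lower number from compound 3 to compound 4 (0.52 log units; beyond the scatter) is the expected size of this change. Compound 4 is estimated at 300 nM, with a likely range from 80 nM to 1200 nM.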

Compound 4, effective concentration (reported as EC, without a stated level of effect): 10 nM
For compound 4 the middle estimate is 30-fold (1.48 log units) above the measured one; measured number outside the range, below it.
By their numbers in this assay, from the lowest: compound 4; then compounds 1 and 2 (each within the scatter of the next); then compound 3.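

In this assay, among the compounds shown here, the earlier compounds showed only that the fluoro groups gave lower numbers than 4-methoxyphenyl, whereas pyridin-3-yl now gives the lowest number of the four, with a 100-fold lower number from compound 3 to compound 4 (2.00 log units; beyond the scatter), a 10-fold lower number from compound 2 to compound 4 (1.00 log units; beyond the scatter) and a 10-fold lower number from compound 1 to compound 4 (1.00 log units; beyond the scatter). This position on the carbonyl carbon therefore spans a much wider range than the first three compounds revealed, and replacing a ring of carbon only with a ring holding one hetero atom goes with the largest step seen so far, even though the entering and leaving groups have the same count of hydrogen-bond acceptors. For the compounds shown here, nothing available explains why this change lowers the number so far.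

The compounds shown leave open whether the result depends on where the nitrogen stands in the ring, which a pyridin-4-yl group would test, and how a plain phenyl group would compare. They also leave open whether pyridin-3-yl would lower the number to a similar extent if the sulfonamide carried a methyl group instead of the ring it has in the shared core.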